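Working notes toward compound 3 in the paw edema series

The source may report more compounds than this note shows. Statements on the series, on what has been measured and on what is new or still open speak of the compounds shown alone.

Measured so far:
Compound 1 `C/C(=N\OCC(=O)O)c1cccc(Cl)c1`: 20%
Compound 2 `C/C(=N\OCC(=O)O)c1ccc(CC2CCCCC2)cc1`: < 20%

In a functional assay on the whole organism for inhibition, with Rattus norvegicus as the target, read by paw edema, with stated times of 1 h and 3 h, at a dose of 50 mg/kg by the oral route (a lower number here means less inhibition, a higher number more inhibition at the dose given (going by the name of the read-out)), compound 1 gives 20%. Compound 2 reaches only a limit of the assay, < 20%, and therefore stands at the lower end of the numbers shown (the limit of < 20% in this assay, at which 1 of the 2 values shown sits). Compound 3 `CSc1ccc(/C(C)=N/OCC(=O)O)cc1` differs from compound 2 in one place: methylsulfanyl in place of cyclohexylmethyl on an aromatic carbon. For the measured compounds named here, no measured pair of the series covers this change, so the expected step of a number no lower from compound 2 to compound 3 (the limit leaves the size open) is taken as none beyond the scatter. Compound 3 is estimated at 20%, between 5% and 35%, and a limit rather than a number remains quite possible.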

Compound 3, a percentage reported as inhibition, in the whole organism at one dose (the size of the read-out at that dose, not a potency): < 20%
Compound 3 gave a limit, no number; the forecaster's own chance of this, stated with the estimate: 40%; the middle value sits exactly at the limit.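

For the compounds shown here, no step from compound 2 to compound 3 can be read in this assay: each gives only a limit, not a number. As far as these compounds go, whether methylsulfanyl in place of cyclohexylmethyl on an aromatic carbon changes the inhibition at all remains open.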